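Series notes: fluoro in place of hydrogen on compound 3

The source may hold more compounds than are shown below. What is called first, only, known or untested is meant among the compounds shown, and "the series" means these compounds.

Measured so far in a functional assay on HT-29 cells (Homo sapiens) for cytotoxicity, read by MTT assay, with a stated time of 72 h; a higher number here means a weaker inhibitor, a lower number a stronger inhibitor:
compound 1 `CN(C)CCCNc1nc(-c2ccc(NC(=O)Nc3ccccc3Cl)cc2)nc2ccsc12`: 390 nM
compound 2 `CN(C)CCCNc1nc(-c2ccc(NC(=O)Nc3ccccc3Cl)cc2)nc2c(Cl)c(Cl)sc12`: 820 nM
compound 3 `CN(C)CCNc1nc(-c2ccc(NC(=O)Nc3ccccc3)cc2)nc2ccsc12`: 620 nM

Compound 3 sits second highest of the three numbers in this assay. Its gap to compound 2 is within the scatter, and its gap to compound 1 is within the scatter as well, so no order among the three can be read from these numbers. Among the measured compounds shown here, compound 1 and compound 2 each differ from compound 3 in more than one place, and no single-change step between measured compounds is available.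

Compound 4 `CN(C)CCNc1nc(-c2ccc(NC(=O)Nc3ccccc3F)cc2)nc2ccsc12` is the next member. From compound 3 to compound 4 the change is fluoro in place of hydrogen on an aromatic carbon, the phenyl becoming a 2-fluorophenyl on the urea end of the molecule. For the measured compounds named here, no measured pair shows what this change does on its own; the nearest point of reference is compound 1, which carries a chloro at the same place together with a longer chain and gives 390 nM, within the scatter of compound 3.

The step from compound 3 to compound 4 is therefore expected to be small, a 1.2-fold lower number from compound 3 to compound 4 (0.09 log units; within the scatter), not beyond the usual scatter in either direction. Compound 4 is estimated at 500 nM, with a range from 250 nM to 1200 nM.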

Compound 4, half-maximal inhibitory concentration: 510 nM
Beside the measured number, compound 4's estimate is 1.0-fold (0.01 log units) below it; measured number inside the range.
By their numbers in this assay, from the lowest: compounds 1, 4, 3 and 2 (each within the scatter of the next, the first and the last beyond it).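

Working notes on the urea end: in this assay, fluoro in place of hydrogen on an aromatic carbon, ortho to a large group, gives a 1.2-fold lower number from compound 3 to compound 4 (0.08 log units; within the scatter), so phenyl and 2-fluorophenyl cannot be told apart by this read-out. Among the compounds shown here, this is the first step that isolates a single change, and it gives this position a direct reading that compounds 1, 2 and 3 could not provide: this one substitution leaves the number within the scatter. No measured data on any property of these compounds bear on this result, and the step stays without an explanation.

On these data alone, whether a methoxy or a trifluoromethyl group at the same place would give a step beyond the scatter remains open, and one fluoro substitution on one side chain does not settle how the position behaves in general. The contribution of the chloro in compound 1 also stays unresolved, since it comes together with a longer chain, and the effect of replacing the dimethylamino group with a morpholine is likewise unknown.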